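Nitro-bearing aryl on the triazole of compound 3

The compounds below may be only part of what the source reports. "The series", "measured", "known", "first", "only" and "open" are said of these compounds alone.

Compound 3 `N#CC1=C(N)Oc2c(N)cc3nc4ccccc4nc3c2C12C(=O)N(Cc1cnnn1-c1ccc(F)c(Cl)c1)c1ccccc12` sits at the ceiling of an ADME assay on L02 cells (Homo sapiens) for antiproliferative activity, read by MTT assay, with a stated time of 48 h; on this read-out higher numbers stand for weaker inhibition and lower numbers for stronger inhibition: in it compound 3 gives > 50000 nM, a limit of the assay rather than a number. Compound 2 `Cc1ccc(-n2nncc2CN2C(=O)C3(C(C#N)=C(N)Oc4c(N)cc5nc6ccccc6nc5c43)c3ccccc32)cc1C` likewise gives > 50000 nM, also a limit. Compound 1 `N#CC1=C(N)Oc2c(N)cc3nc4ccccc4nc3c2C12C(=O)N(Cc1cnnn1-c1cccc(C(F)(F)F)c1)c1ccccc12` gives 38100 nM. The measured steps are an at least 1.3-fold higher number from compound 1 to compound 2 (0.11 log units; that floor lies within the scatter), an at least 1.3-fold higher number from compound 1 to compound 3 (0.11 log units; that floor lies within the scatter) and a step that the two limits leave unreadable from compound 2 to compound 3; the limit of > 50000 nM in this assay, at which 2 of the 3 values shown sit, holds two of the three values, leaving no readable direction among them. Compound 4 `N#CC1=C(N)Oc2c(N)cc3nc4ccccc4nc3c2C12C(=O)N(Cc1cnnn1-c1ccc(Cl)cc1[N+](=O)[O-])c1ccccc12` carries 4-chloro-2-nitrophenyl in place of 3-chloro-4-fluorophenyl on an aromatic nitrogen. With all three aryl variations on the same triazole sitting at or near the limit, compound 4 is expected at 50000 nM, within 20000 nM to 120000 nM, most likely reported as a limit once more. That expectation corresponds to a number no higher from compound 3 to compound 4 (the limit leaves the size open).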

Compound 4, half-maximal inhibitory concentration: > 50000 nM
Compound 4 gave a limit, no number (the forecaster's own chance of this, stated with the estimate: 60%); the middle value sits exactly at the limit.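

The 4-chloro-2-nitrophenyl group of compound 4 shows that a nitro-bearing aryl on this aromatic nitrogen also stays at the limit of this assay, giving no number. The steps to compound 4 from compound 2 and compound 3 cannot be read: both ends are limits. The only readable step is an at least 1.3-fold higher number from compound 1 to compound 4 (0.11 log units; that floor lies within the scatter), and the four aryl groups remain unordered: the limit of > 50000 nM in this assay, at which 3 of the 4 values shown sit.

Still open, going by these compounds, is whether an aminophenyl or carboxyphenyl group on this nitrogen, or a longer alkyl chain in place of the aryl ring, would give a number below the limit.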